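A 4-cyanophenyl swap on the shared core

This account rests on a few compounds, and the source may have more. Where it says the series, first, only, none or still open, it means among the compounds named here.

Going by the values given here, in an in vitro ADME assay on microsomes from liver (Homo sapiens) for metabolic stability, tested at 1 uM (on this read-out higher numbers stand for a longer-lived compound and lower numbers for a shorter-lived compound), this series so far offers limits only. Compound 1 (`COc1ccc(-c2cc(-c3ccc(S(C)(=O)=O)cc3)cnc2N)cn1`) gives > 1.65 h, which is a limit and not a number. Compound 2 (`CS(=O)(=O)c1ccc(-c2cnc(N)c(-c3ccc(CO)nc3)c2)cc1`) gives > 4.16 h, likewise a limit, so its position is open-ended and it has no exact value to serve as a starting point.

Compound 3 (`CS(=O)(=O)c1ccc(-c2cnc(N)c(-c3ccc(C#N)cc3)c2)cc1`) carries 4-cyanophenyl in place of 6-(hydroxymethyl)pyridin-3-yl on an aromatic carbon.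

Among the compounds with values here, the only measured step, a step that the two limits leave unreadable from compound 1 to compound 2, touches the group that leaves here, but its two limits give it no readable size. From the compounds shown here alone, with no size to carry over, no shift beyond the scatter is expected in this assay, and the direction stays open. The estimated step is a step that the limit leaves unreadable from compound 2 to compound 3. Compound 3 is expected at 4.5 h, with an estimated range of 1.8 h to 11 h.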

Compound 3, half-life: > 5.83 h
Compound 3 ended at the assay's limit (the forecaster's own chance of this, stated with the estimate: 55%); at least 1.2-fold (0.11 log units) between middle value and limit.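

In this assay compound 3 gives > 5.83 h, which is a limit and not a number. Going by these compounds alone, compound 1 and compound 2 also stand at limits, so no step among the three can be read. The compounds shown leave open their exact half-lives and their order.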